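The source may hold more compounds than are shown below. What is called first, only, known or untested is meant among the compounds shown, and "the series" means these compounds.

Measured compounds. Compound 1 `O=C1N[C@H](C(=O)O)Cc2ccc(nc2)OCCCCOc2ccc(Cl)c1c2` gives 792 nM in an assay on a protein complex for antagonist activity at integrin alpha2/beta1 (Homo sapiens), read by ELISA, with a stated time of 3 h; a lower number here means a stronger inhibitor, a higher number a weaker inhibitor. Compound 2 `O=C1N[C@H](C(=O)O)Cc2cn(nn2)C/C=C/COc2ccc(Cl)c1c2` gives 34 nM in this assay. Compound 3 `O=C1N[C@@H](C(=O)O)Cc2cn(cn2)CCCCOc2ccc(Cl)c1c2` gives > 4000 nM in this assay.

The value for compound 3 is a limit of the assay rather than a number, so compound 3 sits at the limit of > 4000 nM in this assay, at which 1 of the 3 values shown sits. Compound 4 `O=C1N[C@H](C(=O)O)Cc2cn(cn2)CCCCOc2ccc(Cl)c1c2` keeps every atom and bond of compound 3 and changes only the drawn configuration: the two compounds have the same atoms and bonds and differ only in configuration as drawn: 1 of 1 stereo elements differ; a stereocentre at a saturated ring carbon is drawn R in compound 3 and S in compound 4. Compound 4 is drawn with the same configuration as compound 1 and compound 2, both of which give numbers rather than limits. Going by the values given here, no measured step joins compound 3 and compound 4. The expected step, an at least 13-fold lower number from compound 3 to compound 4 (1.12 log units; beyond the scatter), is toward a stronger inhibitor and beyond the scatter. Compound 4 is estimated at 300 nM, within a range from 60 nM to 1500 nM.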

Compound 4, half-maximal inhibitory concentration: 366 nM
Compound 4: the middle estimate sits 1.2-fold (0.09 log units) below what was measured; the range from low to high includes it.
By their numbers in this assay, from the lowest: compound 2; then compound 4; then compound 1. At a limit, above all of these: compound 3.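

In this assay, going by these compounds alone, drawing the stereocentre at a saturated ring carbon as S rather than R gives an at least 10-fold lower number from compound 3 to compound 4 (1.03 log units; beyond the scatter), a comparison none of the earlier compounds allowed. From the compounds shown here alone, compound 3 stands at a limit of the assay rather than a number, so the full size of this step stays unknown: the limit of > 4000 nM in this assay, at which 1 of the 4 values shown sits. The gap can be placed on configuration alone because nothing else changes: the fact that compounds 3 and 4 differ only in the configuration as drawn

Going by these compounds, whether the same configuration change would matter as much in compound 1 or compound 2 remains open. So does how a methyl ester in place of the carboxylic acid would behave in compound 4.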